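The source may report more compounds than this note shows. Statements on the series, on what has been measured and on what is new or still open speak of the compounds shown alone.

Measured so far in an ADME assay on MT4 cells (Homo sapiens) for cytotoxicity, read by MTT assay; on this read-out lower numbers stand for higher toxicity in this test and higher numbers for lower toxicity in this test:
compound 1 `CCOC(=O)/C(O)=C/C(=O)c1cn(Cc2cc(F)cc(F)c2)c2cccc(OC)c12` gives 34700 nM;
compound 2 `CCOC(=O)/C(O)=C/C(=O)c1cn(Cc2cccc(F)c2F)c2cccc(OC)c12` gives 21100 nM;
compound 3 `COc1cccc2c1c(C(=O)/C=C(\O)C(=O)O)cn2Cc1ccc(F)c(F)c1F` gives 22800 nM.

Compound 3 holds the second highest of the three numbers, yet all three lie within the usual scatter of one another, so no ordering among them can be read. Compound 4 `CCOC(=O)/C(O)=C/C(=O)c1cn(Cc2ccc(F)c(F)c2F)c2cccc(OC)c12` carries ethyl in place of hydrogen on an oxygen next to a carbonyl group. Going by the values given here, the one measured step, a 1.6-fold lower number from compound 1 to compound 2 (0.22 log units; within the scatter), changes only the fluorine pattern on the phenyl group and leaves the ethoxycarbonyl untouched, so it does not bear on this change; no measured pair compares hydrogen with ethyl on that oxygen. Still, compounds 1 and 2, both bearing ethoxycarbonyl, sit close to compound 3, which bears carboxy. The expected step is therefore a 1.1-fold higher number from compound 3 to compound 4 (0.02 log units; within the scatter), nothing beyond the scatter. The estimate for compound 4 is 24000 nM, ranging from 10000 nM to 55000 nM.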

Compound 4, half-maximal cytotoxic concentration: 42700 nM
Compound 4: the middle estimate sits 1.8-fold (0.25 log units) below what was measured, within the range that was stated.
By their numbers in this assay, from the lowest: compounds 2, 3, 1 and 4 (each within the scatter of the next, the first and the last beyond it).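

In this assay ethyl in place of hydrogen on the oxygen next to a carbonyl group gives a 1.9-fold higher number from compound 3 to compound 4 (0.27 log units; within the scatter) and so this first direct comparison of carboxy with ethoxycarbonyl shows no readable change. Fluoro in place of hydrogen on an aromatic carbon gives a 2.0-fold higher number from compound 2 to compound 4 (0.31 log units; beyond the scatter) which is modest but beyond the scatter, while 2,3,4-trifluorophenyl in place of 3,5-difluorophenyl gives a 1.2-fold higher number from compound 1 to compound 4 (0.09 log units; within the scatter) and stays within it. No outside measurement helps to explain these numbers. As far as these compounds go, whether a longer chain such as propyl on that oxygen, or an amide in place of the ester, would move the number stays open. A single pair also cannot show whether ethyl and hydrogen compare alike under other fluorine patterns.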